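Formyl in place of vinyl: what to expect of compound 4

The source may report more compounds than this note shows. Statements on the series, on what has been measured and on what is new or still open speak of the compounds shown alone.

In a functional assay on P388 cells (Mus musculus) for cytotoxicity (on this read-out higher numbers stand for weaker inhibition and lower numbers for stronger inhibition), compound 1 `COC(=O)CC[C@@H]1NC(=O)[C@@H](C)NC(=O)[C@@H]2Cc3ccc(OC)c(c3)Oc3ccc(cc3)C[C@@H](C(=O)N2C)N(C)C(=O)[C@H](C)NC(=O)[C@H](Cc2ccc(OC)cc2)N(C)C1=O` gives 58.9 nM, compound 2 `COc1ccc(C[C@H]2C(=O)N[C@@H](C)C(=O)N(C)[C@H]3Cc4ccc(cc4)Oc4cc(ccc4OC)C[C@@H](C(=O)N[C@H](C)C(=O)N[C@@H](CCCO)C(=O)N2C)N(C)C3=O)cc1` gives 174 nM, and compound 3 `C=CC[C@@H]1NC(=O)[C@@H](C)NC(=O)[C@@H]2Cc3ccc(OC)c(c3)Oc3ccc(cc3)C[C@@H](C(=O)N2C)N(C)C(=O)[C@H](C)NC(=O)[C@H](Cc2ccc(OC)cc2)N(C)C1=O` gives 38.9 nM. Compound 3 therefore has the lowest number of the three, although its lead over compound 1 does not clear the scatter. Its distance from compound 2 does.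

The unmeasured compound 4 `COc1ccc(C[C@H]2C(=O)N[C@@H](C)C(=O)N(C)[C@H]3Cc4ccc(cc4)Oc4cc(ccc4OC)C[C@@H](C(=O)N[C@H](C)C(=O)N[C@@H](CC=O)C(=O)N2C)N(C)C3=O)cc1` differs from compound 3 in one place: formyl in place of vinyl on a saturated chain carbon bound to a saturated ring carbon.

Within the data shown here, two measured steps bear on this change, as both exchange another group for vinyl at that place. They are a 1.5-fold lower number from compound 1 to compound 3 (0.18 log units; within the scatter) and a 4.5-fold lower number from compound 2 to compound 3 (0.65 log units; beyond the scatter). Neither involves formyl, so they offer only a loose guide, but read in reverse they suggest a small move upward at most to a modest one.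

A small step toward a higher number is expected, a 1.9-fold higher number from compound 3 to compound 4 (0.29 log units; within the scatter). The estimated value for compound 4 is 75 nM, with an expected range of 28 nM to 200 nM.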

Compound 4, half-maximal inhibitory concentration: 33.9 nM
Estimate against measurement, compound 4: 2.2-fold (0.34 log units) above; measured number inside the range.
By their numbers in this assay, from the lowest: compounds 4, 3 and 1 (each within the scatter of the next); then compound 2.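

In this assay, formyl in place of vinyl on this saturated chain carbon gives a 1.1-fold lower number from compound 3 to compound 4 (0.06 log units; within the scatter), so this exchange, which brings in one hydrogen-bond acceptor where vinyl has none, leaves the read-out within the scatter. Formyl likewise cannot be separated from (methoxycarbonyl)methyl, at a 1.7-fold lower number from compound 1 to compound 4 (0.24 log units; within the scatter), whereas the step from 2-hydroxyethyl, a 5.1-fold lower number from compound 2 to compound 4 (0.71 log units; beyond the scatter), clears the scatter, leaving compound 2 as the only one of the four set apart at this place. Nothing measured here accounts for why compound 2 alone stands apart.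

From the compounds shown here alone, whether an amine or a carboxylic acid at this place would stay with formyl, vinyl and (methoxycarbonyl)methyl or fall with 2-hydroxyethyl remains open. A longer chain ending in formyl is equally unresolved by the compounds shown.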